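Dialkylamino variation on the pyrazolopyridine series

The source may hold more compounds than are shown below. What is called first, only, known or untested is meant among the compounds shown, and "the series" means these compounds.

Measured compounds:
compound 1 `CCCCNc1cc(C)nc2c(-c3ccc(Cl)cc3Cl)nn(C)c12` — 170 nM
compound 2 `CCCN(CC)c1cc(C)nc2c(-c3ccc(Cl)cc3Cl)nn(C)c12` — 4.1 nM
compound 3 `CCCCCN(CC1CC1)c1cc(C)nc2c(-c3ccc(Cl)cc3Cl)nn(C)c12` — 1.5 nM

In an assay on HEK293 cells for displacement of a labelled ligand from corticotropin-releasing factor receptor 1 (Homo sapiens) (a lower number here means a stronger inhibitor, a higher number a weaker inhibitor), compound 2 gives 4.1 nM, the second highest of the three numbers; compound 3 with 1.5 nM stands nearest and compound 1 with 170 nM furthest. Among the measured compounds shown here, the one single-point step so far, a 41-fold lower number from compound 1 to compound 2 (1.62 log units; beyond the scatter), replaces a secondary amine by a tertiary one on the shared core and is the largest movement in the set.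

Compound 4 `CCCCN(CCCC)c1cc(C)nc2c(-c3ccc(Cl)cc3Cl)nn(C)c12` keeps the tertiary amine and differs from compound 2 only in the side chains: dibutylamino in place of ethyl(propyl)amino on an aromatic carbon. For the measured compounds named here, no measured step bears on this change directly. Compound 3, also a tertiary amine with two chains, gives 1.5 nM, and compound 2 gives 4.1 nM; both are tightly grouped against compound 1. Exchanging one tertiary amine for another is therefore expected to move the number little, most likely within or just beyond the scatter, with a slight lean toward the lower side seen for compound 3. Compound 4 is expected to give 3 nM in this assay, in the range 1 nM to 9 nM. The step of a 1.4-fold lower number from compound 2 to compound 4 (0.14 log units; within the scatter) is the estimated consequence.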

Compound 4, inhibition constant: 0.62 nM
Beside the measured number, compound 4's estimate is 4.8-fold (0.68 log units) above it; the measured number lies below the stated range.
By their numbers in this assay, from the lowest: compound 4; then compound 3; then compound 2; then compound 1.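

In this assay, the tertiary amines at this position are not interchangeable: dibutylamino in place of ethyl(propyl)amino gives a 6.6-fold lower number from compound 2 to compound 4 (0.82 log units; beyond the scatter), although neither group has a ring or a hydrogen-bond donor. Butyl in place of hydrogen on the nitrogen of compound 1 gives a 270-fold lower number from compound 1 to compound 4 (2.44 log units; beyond the scatter), so the size of the gain from secondary to tertiary amine depends on which chains the nitrogen carries. No supporting data bear on the origin of either step.

The compounds shown leave open whether the number keeps falling with a longer chain such as dipentylamino or turns back up. Both chains lengthen together from compound 2 to compound 4, so the separate contribution of each remains unresolved, as does the effect of an ether oxygen in the chains, as in bis(2-methoxyethyl)amino.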